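The source may hold more compounds than are shown below. What is called first, only, known or untested is meant among the compounds shown, and "the series" means these compounds.

Compound 1 `O=C1N/C(=C\c2ccc(O)cc2)C(=O)N1c1ccc(I)cc1` stands second highest of the three numbers in a functional assay on NCI-H292 cells (Homo sapiens) for antiproliferative activity (on this read-out higher numbers stand for weaker inhibition and lower numbers for stronger inhibition), where compound 1 gives 25500 nM. Compound 2 `O=C(Nc1ccc(Cl)cc1)c1cccc(N2C(=O)N/C(=C\c3ccc(O)cc3)C2=O)c1` gives 125000 nM in this assay, and compound 3 `O=C(NCC1CCCCC1)c1cccc(N2C(=O)N/C(=C\c3ccc(O)cc3)C2=O)c1` gives 17900 nM. Compound 4 `O=C(NCc1ccccc1)c1ccc(N2C(=O)N/C(=C\c3ccc(O)cc3)C2=O)cc1` differs from compound 1 by benzylcarbamoyl in place of iodo on an aromatic carbon. For the measured compounds named here, only one measured step bears on this, and indirectly: a 7.0-fold lower number from compound 2 to compound 3 (0.84 log units; beyond the scatter), a modest step in which cyclohexylmethyl replaces 4-chlorophenyl on the amide nitrogen; the benzylcarbamoyl of compound 4 resembles the cyclohexylmethyl amide of compound 3 more than the aryl amide of compound 2. Going by the values given here, no step exchanges iodo for an amide, and compound 1 and compound 3 lie within the scatter of each other. A step within the scatter is therefore expected: a 1.3-fold lower number from compound 1 to compound 4 (0.11 log units; within the scatter). Compound 4 is estimated at 20000 nM, between 6000 nM and 80000 nM.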

Compound 4, half-maximal inhibitory concentration: > 200000 nM
Compound 4: only a limit was reported; the forecaster's own chance of this, stated with the estimate: 10%; at least 10-fold (1.00 log units) between middle value and limit.
By their numbers in this assay, from the lowest: compounds 3 and 1 (each within the scatter of the next); then compound 2. At a limit, above all of these: compound 4.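

In this assay, benzylcarbamoyl in place of iodo, on an aromatic carbon para to a large group, is not a neutral exchange: it gives an at least 7.8-fold higher number from compound 1 to compound 4 (0.89 log units; beyond the scatter). Compound 4 is recorded only as a limit, so this step has no upper end: the limit of > 200000 nM in this assay, at which 1 of the 4 values shown sits. The earlier compounds shown here offered only a change on the amide nitrogen, whereas this step shows that replacing iodo at this position can weaken inhibition.

The compounds shown leave open whether the loss follows the amide or the benzyl ring. Going by these compounds, how an amine or a carboxylic acid would behave at this position also stays open.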